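The source may hold more compounds than are shown below. What is called first, only, known or untested is meant among the compounds shown, and "the series" means these compounds.

Of the compounds shown here, three built on the same core have been measured in a functional assay on DU-145 cells (Homo sapiens) for cytotoxicity, read by MTT assay; on this read-out higher numbers stand for weaker inhibition and lower numbers for stronger inhibition. Compound 1 `CCCCC(O)CC(=O)O[C@H](CC=C(C)C)C1=CC(=O)c2c(O)ccc(O)c2C1=O` gives 45300 nM. Compound 2 `COC(C)CO[C@H](CC=C(C)C)C1=CC(=O)c2c(O)ccc(O)c2C1=O` gives 16600 nM. Compound 3 `CC(C)=CC[C@@H](OC(=O)C1CCCO1)C1=CC(=O)c2c(O)ccc(O)c2C1=O` gives 10500 nM, the lowest of the three numbers, though its gap to compound 2, a 1.6-fold lower number from compound 2 to compound 3 (0.20 log units; within the scatter), lies within the scatter, while its gap to compound 1, a 4.3-fold lower number from compound 1 to compound 3 (0.63 log units; beyond the scatter), does not.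

Compound 4 `CC(C)=CC[C@@H](OC(=O)C1CCCOC1)C1=CC(=O)c2c(O)ccc(O)c2C1=O` differs from compound 3 in one place: oxan-3-yl in place of oxolan-2-yl on a carbonyl carbon. Going by the values given here, no measured step changes only a ring in this way. The step that comes closest, a 4.3-fold lower number from compound 1 to compound 3 (0.63 log units; beyond the scatter), swaps a whole open chain for a ring on the carbonyl carbon and was modest; the step of a 2.7-fold lower number from compound 1 to compound 2 (0.44 log units; beyond the scatter) replaces the entire ester and was modest too. Both show that changes at this ester move the number only moderately. The expected step from compound 3 to compound 4, a 1.0-fold higher number from compound 3 to compound 4 (0.02 log units; within the scatter), is therefore none beyond the scatter. Compound 4 is estimated at 11000 nM, within a range from 4000 nM to 30000 nM.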

Compound 4, half-maximal inhibitory concentration: 29700 nM
Compound 4: middle estimate off by 2.7-fold (0.43 log units), on the low side; the range from low to high includes it.
By their numbers in this assay, from the lowest: compounds 3, 2, 4 and 1 (each within the scatter of the next, the first and the last beyond it).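

Exchanging only the ring on the carbonyl carbon, with the ester kept, is enough to move the number: oxan-3-yl in place of oxolan-2-yl gives a 2.8-fold higher number from compound 3 to compound 4 (0.45 log units; beyond the scatter) as a modest step. This position therefore responds to the identity of the ring, and not only to the loss of a whole open chain or of the entire ester. The steps of a 1.8-fold higher number from compound 2 to compound 4 (0.25 log units; within the scatter) and a 1.5-fold lower number from compound 1 to compound 4 (0.18 log units; within the scatter) leave compound 4 not separable from compound 2 or compound 1, and nothing measured here accounts for the shift seen with the new ring.

This step changes ring size and the point of attachment together, and an oxan-2-yl or an oxolan-3-yl group on the same carbonyl carbon would tell these two changes apart. On these data alone, how an amine on the ring would behave at this place also remains open.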